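The compounds below may be only part of what the source reports. "The series", "measured", "known", "first", "only" and "open" are said of these compounds alone.

Working notes on the series. Among the compounds with values here, compound 3 `CC(c1ccccc1)c1cc2c(N)nc(-c3cccc(C#N)c3)nc2s1` is the only member that gives a plain number in a functional assay on CHO-K1 cells for antagonist activity at adenosine receptor A1 (Homo sapiens), read by a beta-galactosidase reporter and cAMP accumulation, with stated times of 15 min and 6 h (on this read-out lower numbers stand for stronger inhibition and higher numbers for weaker inhibition), where compound 3 reads 1770 nM. Compound 2 `N#Cc1cccc(-c2nc(N)c3cc(Cc4ccccc4F)sc3n2)c1` stops at a limit in this assay, < 16 nM. Compound 1 `Cc1csc(-c2nc(N)c3cc(C4(c5ccccc5)CC4)sc3n2)n1`, which carries the 1-phenylcyclopropyl group but a different aryl partner, also stops at a limit, > 610 nM. Within the data shown here, the one measured step runs an at least 110-fold higher number from compound 2 to compound 3 (2.04 log units; beyond the scatter); it starts from the limit of compound 2, (the limit of < 16 nM in this assay, at which 1 of the 3 values shown sits), so its true size is a lower bound. Among the measured compounds shown here, compound 4 `N#Cc1cccc(-c2nc(N)c3cc(C4(c5ccccc5)CC4)sc3n2)c1` differs from compound 3 by 1-phenylcyclopropyl in place of 1-phenylethyl on an aromatic carbon, and no measured step follows this particular change. For the measured compounds named here, compound 1 with the same 1-phenylcyclopropyl group sits at the limit (the limit of > 610 nM in this assay, at which 1 of the 3 values shown sits), which says only that compound 1 is weak. The change from compound 3 to compound 4 keeps the phenyl and the aryl nitrile and only closes the ethyl into a small ring, so no large movement in this assay is expected; the estimated step is a 1.2-fold higher number from compound 3 to compound 4 (0.09 log units; within the scatter). Compound 4 is therefore expected to come in at 2200 nM, within a range of 600 nM to 8000 nM, with some chance that this assay again reports only a limit.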

Compound 4, inhibition constant: > 610 nM
Compound 4 was reported as a limit; the forecaster's own chance of this, stated with the estimate: 25%; the middle value does not contradict the limit.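

In this assay compound 4 gives > 610 nM as a limit and not a number. On the aromatic carbon next to the ring sulfur, with the 3-cyanophenyl group unchanged, 1-phenylcyclopropyl in place of 2-fluorobenzyl gives an at least 38-fold higher number from compound 2 to compound 4 (1.58 log units; beyond the scatter) and so joins 1-phenylethyl as a second replacement that moves the number up beyond the scatter; compound 2 stands at a limit, so this step is only a lower bound. The steps from compound 3 to compound 4 and from compound 1 to compound 4 cannot be read, so neither closing the ethyl into the three-membered ring nor exchanging 4-methyl-1,3-thiazol-2-yl for 3-cyanophenyl has a size here.

Still open, from the compounds shown here alone, is how far past its limit compound 4 truly lies, and so whether 1-phenylcyclopropyl and 1-phenylethyl differ at all in this assay on this position. Also open, going by these compounds, is how the unsubstituted benzyl group, a longer chain such as 2-phenylethyl, an aminomethyl group or a carboxylic acid would read on the same carbon.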